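Ether for Amine at the Aryl Terminus: Compound 4

The source may hold more compounds than are shown below. What is called first, only, known or untested is meant among the compounds shown, and "the series" means these compounds.

In an ADME assay on Vero cells (Chlorocebus sabaeus) for cytotoxicity, read by MTT assay, with a stated time of 72 h (a higher number here means that more compound is tolerated, a lower number that less compound is tolerated), compound 1 `Nc1ccc(/C=C/C(=O)Nc2nnc(-c3ccccc3)[nH]2)cc1` gives 1910000 nM, the highest of the three numbers measured, though compound 3 `O=C(/C=C/c1ccc([N+](=O)[O-])s1)Nc1nnc(-c2ccccc2)[nH]1` with 1670000 nM and compound 2 `O=C(/C=C/c1ccc(Cl)cc1)Nc1nnc(-c2ccccc2)[nH]1` with 1620000 nM lie within the scatter of it. Compound 4 `C=C(C)COc1ccc(/C=C/C(=O)Nc2nnc(-c3ccccc3)[nH]2)cc1` differs from compound 1 by (2-methylprop-2-en-1-yl)oxy in place of amino on an aromatic carbon. The step that bears most on this is a 1.2-fold lower number from compound 1 to compound 2 (0.07 log units; within the scatter), which also exchanges the amino group on that aromatic carbon; a 1.1-fold lower number from compound 1 to compound 3 (0.06 log units; within the scatter) and a 1.0-fold higher number from compound 2 to compound 3 (0.01 log units; within the scatter) replace the whole aryl terminus and are likewise within the scatter. Compound 4 is therefore expected to show no step beyond the scatter in this assay, estimated as a 1.1-fold lower number from compound 1 to compound 4 (0.03 log units; within the scatter). Compound 4 is estimated at 1800000 nM, with a range from 900000 nM to 3600000 nM.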

Compound 4, half-maximal cytotoxic concentration: 1420000 nM
Beside the measured number, compound 4's estimate is 1.3-fold (0.10 log units) above it; low and high end bracket the measured number.
By their numbers in this assay, from the lowest: compounds 4, 2, 3 and 1 (each within the scatter of the next).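

In this assay, (2-methylprop-2-en-1-yl)oxy on an aromatic carbon para to a large group gives a 1.3-fold lower number from compound 1 to compound 4 (0.13 log units; within the scatter) in place of amino and a 1.1-fold lower number from compound 2 to compound 4 (0.06 log units; within the scatter) in place of chloro. This shows that a branched ether chain with no hydrogen-bond donor and a double bond outside the aromatic rings also stays within the scatter at this position, which the exchange of amino for chloro alone could not show. No evidence bearing on this result is available. Going by these compounds, whether a carboxylic acid or a longer chain at this carbon would also stay within the scatter remains open.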